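Working notes: from compound 3 to compound 4

The source may report more compounds than this note shows. Statements on the series, on what has been measured and on what is new or still open speak of the compounds shown alone.

For the measured compounds named here, compound 3 `COc1ccc(C(=O)/C=C/c2cc(-c3cc(OC)c(OC)c(OC)c3)n[nH]2)cc1` holds the low end of the two numbers so far in a functional assay on MDA-MB-468 cells (Homo sapiens) for inhibition, read by sulforhodamine B assay, with a stated time of 48 h (on this read-out higher numbers stand for lower toxicity in this test and lower numbers for higher toxicity in this test), where compound 3 gives 5450 nM. Compound 1 `COc1cc(-c2cc(/C=C/C(=O)c3ccc(N)cc3)[nH]n2)cc(OC)c1OC` sits close by, giving 8420 nM in this assay; the step of a 1.5-fold lower number from compound 1 to compound 3 (0.19 log units; within the scatter) is within the scatter, so nothing separates the two. Compound 2 `COc1cc(-c2cc(/C=C/C(=O)c3ccc(Cl)c(Cl)c3)[nH]n2)cc(OC)c1OC` returns only a limit in this assay, > 100000 nM. Both large steps seen involve the 3,4-dichlorophenyl group: an at least 11-fold higher number from compound 1 to compound 2 (1.07 log units; beyond the scatter) and an at least 18-fold lower number from compound 2 to compound 3 (1.26 log units; beyond the scatter), each bounded by the limit of > 100000 nM in this assay, at which 1 of the 3 values shown sits.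

Compound 4 `COc1cc(-c2cc(/C=C/C(=O)c3ccc(F)c(F)c3)[nH]n2)cc(OC)c1OC` carries the change (3,4-difluorophenyl in place of 4-methoxyphenyl on a carbonyl carbon). This mirrors the step from compound 2 to compound 3 with fluorine standing where chlorine stood, so a substantial upward step in this assay is expected, although the limit seen in compound 2 leaves the true size of that reference step open. The step of a 7.3-fold higher number from compound 3 to compound 4 (0.87 log units; beyond the scatter) is the expected outcome. Compound 4 is estimated at 40000 nM in this assay, within 12000 nM to 130000 nM, with a real chance that only a limit is returned.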

Compound 4, concentration lethal to 50% of the cells: > 100000 nM
Compound 4 ended at the assay's limit; the forecaster's own chance of this, stated with the estimate: 35%; at least 2.5-fold (0.39 log units) between middle value and limit.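

In this assay the change to 3,4-difluorophenyl on a carbonyl carbon gives an at least 18-fold higher number from compound 3 to compound 4 (1.26 log units; beyond the scatter) and likewise an at least 11-fold higher number from compound 1 to compound 4 (1.07 log units; beyond the scatter) as the second comparison. The large upward move is therefore not confined to the 3,4-dichlorophenyl group: among the compounds shown, the 3,4-difluorophenyl and 3,4-dichlorophenyl compounds stand apart from the 4-methoxyphenyl and 4-aminophenyl compounds. The step from compound 2 to compound 4 cannot be read, because each of the two returns only a limit and not a number: the limit of > 100000 nM in this assay, at which 2 of the 4 values shown sit.

From the compounds shown here alone, how far compound 2 and compound 4 lie past that limit stays open, so fluorine and chlorine cannot be ordered here. Also open, going by these compounds, is whether a 4-fluorophenyl or 4-hydroxyphenyl group on the carbonyl carbon would stay with compound 1 and compound 3 or move to the limit.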